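The compounds below may be only part of what the source reports. "The series", "measured", "known", "first", "only" and "open" are said of these compounds alone.

Working notes on the series.

Two compounds have numbers in a functional assay for activation of Alpha-1A adrenergic receptor (Homo sapiens), read by calcium flux; a higher number here means that more compound is needed for the effect, a lower number that less compound is needed. Compound 2 `c1ccc(-c2ccsc2)c(OCC2=NCCN2)c1` stands at the lowest of the two, giving 0.251 nM. Its nearest neighbour is compound 1 `c1cncc(-c2ccccc2OCC2=NCCN2)c1`, which gives 2 nM. Among the measured compounds shown here, the single measured step, an 8.0-fold lower number from compound 1 to compound 2 (0.90 log units; beyond the scatter), came with thiophen-3-yl in place of pyridin-3-yl on an aromatic carbon.

Compound 3 `c1ccc(-c2nccs2)c(OCC2=NCCN2)c1` is the next member to be measured. Its difference from compound 2 is 1,3-thiazol-2-yl in place of thiophen-3-yl on an aromatic carbon. For the measured compounds named here, only the step from compound 1 to compound 2 bears on this change, and it bears on it loosely: it tells how a six-membered ring with one hetero atom compared with a five-membered ring with one hetero atom at this carbon, not how two five-membered rings with one or two hetero atoms compare. Going by the values given here, no measured pair isolates that second question. The expectation is therefore a step of uncertain direction, kept small, leaning toward a somewhat higher number for compound 3 than compound 2 shows. Compound 3 is estimated at 0.6 nM in this assay, with a range of 0.15 nM to 2.5 nM. The step this estimate implies is a 2.4-fold higher number from compound 2 to compound 3 (0.38 log units; beyond the scatter).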

Compound 3, half-maximal effective concentration: 2.51 nM
Estimate against measurement, compound 3: 4.2-fold (0.62 log units) below; measured number outside the range, above it.
By their numbers in this assay, from the lowest: compound 2; then compounds 1 and 3 (each within the scatter of the next).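

In this assay, this carbon proves sensitive to a change that keeps ring size and heavy-atom count the same: 1,3-thiazol-2-yl in place of thiophen-3-yl, a second hetero atom in the five-membered aromatic ring, gives a step beyond the scatter (a 10-fold higher number from compound 2 to compound 3 (1.00 log units; beyond the scatter)). Ring size alone therefore does not set the number, since the five-membered 1,3-thiazol-2-yl and the six-membered pyridin-3-yl cannot be told apart (a 1.3-fold higher number from compound 1 to compound 3 (0.10 log units; within the scatter)), and among these three compounds only the thiophen-3-yl group, the one ring without a ring nitrogen, stands apart, with no compound shown going against that reading. Nothing at hand gives a reason for the size of either step.

Open, from the compounds shown here alone, is whether the placement of the ring nitrogen counts as much as its presence, a question that 1,3-thiazol-4-yl and 1,3-thiazol-5-yl groups at this carbon would address. Also open, going by these compounds, is whether the sulfur plays any part in the low number of compound 2, which furan-3-yl or plain phenyl in the same place would help to settle.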